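Configuration swap at the hydroxyl ring carbon: compound 3 to 4

The compounds below may be only part of what the source reports. "The series", "measured", "known", "first", "only" and "open" are said of these compounds alone.

Measured in an ADME assay on liver for metabolic stability, with Liver microsome (Homo sapiens) as the target, read by LC-MS, using microsomes, with a stated time of 5 h (on this read-out lower numbers stand for slow clearance and higher numbers for fast clearance), so far:
compound 1 `O[C@H](c1ccccn1)[C@]1(c2cccc(OC(F)(F)F)c2)C[C@H](O)C1` gives 150 mL/min/kg
compound 2 `C[C@]1(O)C[C@](c2cccc(C(F)(F)F)c2)([C@H](O)c2ccccn2)C1` gives 33.3 mL/min/kg
compound 3 `O[C@H](c1ccccn1)[C@]1(c2cccc(C(F)(F)F)c2)C[C@H](O)C1` gives 133 mL/min/kg

Compound 3 stands with compound 1 at the high end of the three, with a 1.1-fold lower number from compound 1 to compound 3 (0.05 log units; within the scatter) for trifluoromethyl in place of trifluoromethoxy on an aromatic carbon. Compound 2 lies apart, with a 4.0-fold higher number from compound 2 to compound 3 (0.60 log units; beyond the scatter) for hydrogen in place of methyl on a saturated ring carbon. Compound 4 `O[C@H](c1ccccn1)[C@]1(c2cccc(C(F)(F)F)c2)C[C@@H](O)C1` differs from compound 3 thus the two compounds have the same atoms and bonds and differ only in configuration as drawn: 2 of 3 stereo elements differ; a stereocentre at a saturated ring carbon is drawn s in compound 3 and r in compound 4; a stereocentre at a saturated ring carbon is drawn R in compound 3 and S in compound 4 and has the same atoms and bonds. Neither measured step is a change of configuration, so neither sizes this one directly. No shift beyond the scatter is expected, and the estimate is a 1.2-fold lower number from compound 3 to compound 4 (0.08 log units; within the scatter) in this assay as a working figure. For compound 4 the estimated value is 110 mL/min/kg with an expected range from 50 mL/min/kg to 200 mL/min/kg as a working figure.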

Compound 4, clearance: 50 mL/min/kg
Compound 4: the middle estimate sits 2.2-fold (0.34 log units) above what was measured, within the range that was stated.
By their numbers in this assay, from the lowest: compounds 2 and 4 (each within the scatter of the next); then compounds 3 and 1 (each within the scatter of the next).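

In this assay the configuration of the saturated ring carbons matters, with a 2.7-fold lower number from compound 3 to compound 4 (0.42 log units; beyond the scatter) at this position. The earlier steps shown here changed atoms, whereas this shift arises with no atom entering or leaving. Configuration alone accounts for it here because nothing else separates the pair: the fact that compounds 3 and 4 differ only in the configuration as drawn.

Going by these compounds, it remains open whether the same swap moves the number with trifluoromethoxy on the aromatic carbon or with methyl on the saturated ring carbon. On these data alone, how an amine in place of the hydroxyl on that ring carbon would read, in either configuration, also remains open.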